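The source may hold more compounds than are shown below. What is called first, only, known or untested is meant among the compounds shown, and "the series" means these compounds.

Among the compounds with values here, in a functional assay on U2OS cells (Homo sapiens) for inhibition, read by CCK-8 assay, with a stated time of 72 h, tested at 1 uM (on this read-out higher numbers stand for more inhibition at the one concentration tested (going by the name of the read-out) and lower numbers for less inhibition), compound 2 `COc1cccc(OC)c1N1C(=O)CSC1c1cccc(C(=O)NCCCCc2ccccc2)c1` gives 41%, the highest of the three numbers measured so far. Compound 1 `COc1ccccc1N1C(=O)CSC1c1cc(F)cc(C(=O)O)c1` gives 15%, and compound 3 `COc1ccccc1N1C(=O)CSC1C(=O)NCCCCc1ccccc1` gives 6%; both stand beyond the usual scatter below compound 2. Within the data shown here, none of these three compounds differ in only one place, so no single step has been measured that would anchor a prediction. Compound 4 `Cc1cccc(N2C(=O)CSC2c2cccc(C(=O)NCCCCc3ccccc3)c2)c1` has not yet been tested; compared with compound 2 it shows (3-methylphenyl in place of 2,6-dimethoxyphenyl on an amide-type nitrogen in a ring). Without a measured step of this kind, only a guarded expectation is possible: a moderate decrease is expected, a step of a number 11 percentage points lower from compound 2 to compound 4 (beyond the scatter) in this assay. Compound 4 is therefore estimated at 30%, within a range of 10% to 55%.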

Compound 4, a percentage reported as inhibition, at one concentration (the size of the read-out at that concentration, not a potency): 39%
For compound 4 the middle estimate is 9 percentage points below the measured one; the measured number falls inside the stated range.
By their numbers in this assay, from the lowest: compounds 3 and 1 (each within the scatter of the next); then compounds 4 and 2 (each within the scatter of the next).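

In this assay, within the data shown here, putting 3-methylphenyl in place of 2,6-dimethoxyphenyl on the amide-type nitrogen in the ring gives a number 2 percentage points lower from compound 2 to compound 4 (within the scatter) and is the first step measured at this position. In this one pair, the two methoxy groups and their oxygens can be lost without a change beyond the scatter, so neither is needed to keep this level of inhibition. Nothing measured here explains this result.

Only one replacement at this position can be read, so the inhibition in this assay may not stay level with other groups. A phenyl ring carrying an amine or a carboxylic acid here could behave quite differently.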